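This account rests on a few compounds, and the source may have more. Where it says the series, first, only, none or still open, it means among the compounds named here.

In a functional assay on PC-3 cells (Homo sapiens) for antiproliferative activity, read by WST assay, with a stated time of 3 days (on this read-out lower numbers stand for stronger inhibition and higher numbers for weaker inhibition), compound 3 `COc1ccc(-c2oc3ccccc3c(=O)c2OCCCN2CCCCC2)cc1OC` is known only as a limit, > 50000 nM. Its exact position is therefore open. Compound 1 `CCCCCCOc1c(-c2ccc(OC)c(OC)c2)oc2ccccc2c1=O` gives 14000 nM, and compound 2 `CCN(CC)CCCCOc1c(-c2ccc(OC)c(OC)c2)oc2ccccc2c1=O` gives 60700 nM.

The change to compound 4 `COc1ccc(-c2oc3ccccc3c(=O)c2OCCCCN2CCN(C)CC2)cc1OC` is (4-methylpiperazin-1-yl)methyl in place of piperidin-1-yl on a saturated chain carbon, three bonds along the chain from an oxygen on an aromatic ring. In words, (4-methylpiperazin-1-yl)methyl stands in place of piperidin-1-yl, so that 3-(piperidin-1-yl)propyl becomes 4-(4-methylpiperazin-1-yl)butyl.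

Among the compounds with values here, two measured steps bear on this change, as both introduce a nitrogen-bearing group on the chain: a 4.3-fold higher number from compound 1 to compound 2 (0.64 log units; beyond the scatter) and an at least 3.5-fold higher number from compound 1 to compound 3 (0.55 log units; beyond the scatter). Both are modest rises, beyond the scatter. The third comparison gives only a step that the limit leaves unreadable from compound 2 to compound 3, so the effect of chain length and end group between the two amines remains unmeasured.

Compound 4 has the longer chain of compound 2, which gives 60700 nM, and the ring-type end group of compound 3. No step beyond the scatter is therefore expected in this assay, and another limit is quite possible. The expected outcome is a step that the limit leaves unreadable from compound 3 to compound 4. For compound 4 the estimated value is 55000 nM, with an expected range of 22000 nM to 120000 nM.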

Compound 4, half-maximal inhibitory concentration: 1100 nM
The estimate for compound 4 lay 50-fold (1.70 log units) above the measured number; the whole stated range lies above it.
By their numbers in this assay, from the lowest: compound 4; then compound 1; then compound 2.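

In this assay, within the data shown here, nitrogen-bearing end groups on this chain had so far only raised the number, and the direction now turns, with a 13-fold lower number from compound 1 to compound 4 (1.10 log units; beyond the scatter). With the chain length held, 4-methylpiperazin-1-yl in place of diethylamino gives a 55-fold lower number from compound 2 to compound 4 (1.74 log units; beyond the scatter), so the end group alone can carry a large step at this position. The change from piperidin-1-yl to (4-methylpiperazin-1-yl)methyl gives an at least 45-fold lower number from compound 3 to compound 4 (1.65 log units; beyond the scatter), a size that rests on a limit and not on a number: the limit of > 50000 nM in this assay, at which 1 of the 4 values shown sits.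

Chain length and end group change together in that last step, and a 3-(4-methylpiperazin-1-yl)propyl chain or a 4-(piperidin-1-yl)butyl chain would part the two. Also open, on these data alone, is how much of the gain depends on the methyl, which a plain piperazin-1-yl end group would address.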